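Replacing a nitrophenyl group with a methoxyphenyl group

This account rests on a few compounds, and the source may have more. Where it says the series, first, only, none or still open, it means among the compounds named here.

Measured in a functional assay on NCI-N87 cells (Homo sapiens) for antiproliferative activity, read by CCK-8 assay, with a stated time of 72 h; on this read-out lower numbers stand for stronger inhibition and higher numbers for weaker inhibition:
Compound 1 `Cc1cc(Nc2cc(N3CCN(C)CC3)nc(Nc3ccc([N+](=O)[O-])cc3)n2)n[nH]1`: 3880 nM
Compound 2 `Cc1cc(Nc2cc(N3CCN(C)CC3)nc(Nc3cccc([N+](=O)[O-])c3)n2)n[nH]1`: 4320 nM

Among the compounds with values here, only two compounds have numbers so far, and compound 2 cannot be told apart from compound 1. Putting 3-nitrophenyl in place of 4-nitrophenyl on a nitrogen on an aromatic ring gave a 1.1-fold higher number from compound 1 to compound 2 (0.05 log units; within the scatter).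

The next compound, compound 3 `COc1ccc(Nc2nc(Nc3cc(C)[nH]n3)cc(N3CCN(C)CC3)n2)cc1`, carries 4-methoxyphenyl in place of 3-nitrophenyl at that same place: 4-methoxyphenyl in place of 3-nitrophenyl on a nitrogen on an aromatic ring. Within the data shown here, the only measured step, a 1.1-fold higher number from compound 1 to compound 2 (0.05 log units; within the scatter), exchanged one nitrophenyl group for another, so it is a weak guide here. Among the measured compounds shown here, no measured compound shows what happens when the nitrophenyl group itself is replaced. In this assay, no step beyond the scatter is expected, and no direction is favoured, although the range must stay wide. The expected change is a 1.2-fold lower number from compound 2 to compound 3 (0.09 log units; within the scatter). For compound 3 the estimate is 3500 nM, with an expected range of 1200 nM to 10000 nM.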

Compound 3, half-maximal inhibitory concentration: 18900 nM
For compound 3 the middle estimate is 5.4-fold (0.73 log units) below the measured one; the measured number lies above the stated range.
By their numbers in this assay, from the lowest: compounds 1 and 2 (each within the scatter of the next); then compound 3.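

In this assay, exchanging one nitrophenyl group for the other had shown no clear change, but this position does respond when the nitro group itself is replaced. Putting 4-methoxyphenyl in place of 3-nitrophenyl gives a 4.4-fold higher number from compound 2 to compound 3 (0.64 log units; beyond the scatter) and putting methoxy in place of nitro on an aromatic carbon gives a 4.9-fold higher number from compound 1 to compound 3 (0.69 log units; beyond the scatter), so both steps are beyond the scatter and compound 3 is the weakest of the three on this read-out. Nothing available explains why this change weakens inhibition.

As far as these compounds go, what remains open is whether the loss comes from removing the nitro group or from adding the methoxy group. A plain phenyl, or a phenyl carrying a nitrile or an amine, could help separate those two possibilities, depending on whether it falls nearer compound 1 or compound 3.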